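Phenol Methylation Across Two Amide-Linked Pyrazole Series

The source may report more compounds than this note shows. Statements on the series, on what has been measured and on what is new or still open speak of the compounds shown alone.

Measured compounds:
compound 1 `O=C(Nc1cccc(-n2cc(-c3ccncc3)c(-c3cc(O)cc(Cl)c3)n2)c1)Nc1ccc(Cl)c(C(F)(F)F)c1` — 42.1%
compound 2 `COc1cc(Cl)cc(-c2nn(-c3cccc(NC(=O)Nc4ccc(Cl)c(C(F)(F)F)c4)c3)cc2-c2ccncc2)c1` — 22.9%
compound 3 `O=C(Nc1cccc(-n2cc(-c3ccncc3)c(-c3cc(O)cc(Cl)c3)n2)c1)c1cc(C(F)(F)F)cc(C(F)(F)F)c1` — 69.4%

In a functional assay on SF-268 cells (Homo sapiens) for inhibition, read by sulforhodamine B assay, with a stated time of 48 h, tested at 10 uM (on this read-out higher numbers stand for a weaker effect at the one concentration tested and lower numbers for a stronger effect), compound 1 gives 42.1% and compound 2 gives 22.9%. The two differ only by methyl in place of hydrogen on an oxygen on an aromatic ring, and this step reads a number 19.2 percentage points lower from compound 1 to compound 2 (beyond the scatter), so the methylated compound shows the stronger effect at the single concentration tested. Compound 3 gives 69.4% in this assay, the highest of the three numbers and beyond the scatter from both compound 1 and compound 2. The difference between the cores of compound 1 and compound 3 is not broken down here.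

Compound 4 `COc1cc(Cl)cc(-c2nn(-c3cccc(NC(=O)c4cc(C(F)(F)F)cc(C(F)(F)F)c4)c3)cc2-c2ccncc2)c1` has not yet been measured. It differs from compound 3 by methyl in place of hydrogen on an oxygen on an aromatic ring, the same change that separates compound 1 from compound 2, with an identical surrounding place on the ring. If the step carries over, compound 4 is expected to move by about a number 17.4 percentage points lower from compound 3 to compound 4 (beyond the scatter) in this assay, resting on the drop seen in a number 19.2 percentage points lower from compound 1 to compound 2 (beyond the scatter) and on the starting point of compound 3 at 69.4%. Compound 4 is therefore estimated at 52%, within 36% to 70%.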

Compound 4, a percentage reported as activity, at one concentration (the size of the read-out at that concentration, not a potency): 89.2%
Compound 4: the middle estimate sits 37.2 percentage points below what was measured, outside the stated range (above it).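

Going from hydroxy to methoxy on the 3-chloro-5-hydroxyphenyl group gives a number 19.8 percentage points higher from compound 3 to compound 4 (beyond the scatter) in this assay, so on this core the methoxy compound shows the weaker effect at the single concentration tested. Set beside the earlier step, the same change runs in opposite directions on the two cores: the same change on two cores in this assay, a number 19.2 percentage points lower (beyond the scatter) from compound 1 to compound 2 and a number 19.8 percentage points higher (beyond the scatter) from compound 3 to compound 4, 39 percentage points apart, beyond the scatter of two such steps

The outcome of this change therefore depends on the core that carries it, and a step read on the core of compound 1 gives no safe direction for the core of compound 3, though two pairs at one concentration neither show which part of the cores is responsible nor say anything about potency.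

Still open, on these data alone, is whether a longer chain on that oxygen, such as ethyl, would follow the direction seen on each core. Also open, as far as these compounds go, is how each core would respond if an amine replaced the hydroxy group.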